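The source may report more compounds than this note shows. Statements on the series, on what has been measured and on what is new or still open speak of the compounds shown alone.

Compound 1 `CC(C)(C)/N=c1\c(O)c(O)\c1=N/c1cccc2cnccc12`: 1840 nM
Compound 2 `CCC(CC)/N=c1\c(O)c(O)\c1=N/c1ccc(C#N)cc1`: 3340 nM

Of the compounds shown here, two have been measured in a functional assay for inhibition, with Rattus norvegicus as the target; on this read-out lower numbers stand for stronger inhibition and higher numbers for weaker inhibition. Compound 1 `CC(C)(C)/N=c1\c(O)c(O)\c1=N/c1cccc2cnccc12` gives 1840 nM there, and compound 2 `CCC(CC)/N=c1\c(O)c(O)\c1=N/c1ccc(C#N)cc1` gives 3340 nM; the two numbers lie within the usual scatter of each other, so neither can be set above the other. Compound 3 `C[C@@H](/N=c1\c(O)c(O)\c1=N/c1ccc(C#N)cc1)C1CCCCC1` is yet to be measured. It differs from compound 2 by 1-cyclohexylethyl in place of pentan-3-yl on a double-bonded nitrogen. Among the compounds with values here, no measured pair tells how this assay responds to such a change, so the step from compound 2 to compound 3 is expected to be small, a 1.3-fold lower number from compound 2 to compound 3 (0.13 log units; within the scatter), in no firm direction beyond the scatter. Compound 3 is therefore estimated at 2500 nM, within 800 nM to 8000 nM.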

Compound 3, half-maximal inhibitory concentration: 2600 nM
Estimate against measurement, compound 3: 1.0-fold (0.02 log units) below; the measured number falls inside the stated range.
By their numbers in this assay, from the lowest: compounds 1, 3 and 2 (each within the scatter of the next).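

In this assay, within the data shown here, 1-cyclohexylethyl in place of pentan-3-yl on a double-bonded nitrogen gives a 1.3-fold lower number from compound 2 to compound 3 (0.11 log units; within the scatter) in the first single-place comparison of the series. The two numbers cannot be told apart, so this position accepts a six-membered non-aromatic carbon ring and a defined stereocentre with no shift beyond the scatter. No evidence accounts for this result. The compounds shown leave open how the opposite stereoisomer of 1-cyclohexylethyl would read, and whether an amine or a carboxylic acid on this chain would move the number.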